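Isopropyl in place of butyl on one chain

A few compounds are considered here, and "the series" means these few. Any claim that something is new, unique, unknown or untested is made for them only; others in the source may bear on it.

In a physicochemical assay for lipophilicity, read by HPLC, using the shake flask method (a lower number here means a more polar compound, a higher number a more lipophilic compound), compound 1 `C/C(=N\C#N)N(Cc1ccc(Cl)nc1)C(C)C` gives 1.46 and compound 2 `CCCCC/C(=N\C#N)N(C)Cc1ccc(Cl)nc1` gives 2.3 as its reading. Compound 2 thus holds the higher of the two numbers, and the gap lies beyond the usual scatter. These two compounds differ in more than one place, so the gap points to no single structural change. Compound 3 `CC(C)C/C(=N\C#N)N(C)Cc1ccc(Cl)nc1` is still unmeasured. It comes from compound 2 by one change (isopropyl in place of butyl on a saturated chain carbon bound to a carbon with a double bond to nitrogen), with isopropyl in place of butyl on a saturated chain carbon bound to a carbon with a double bond to nitrogen. Within the data shown here, no measured pair shows this change alone, so what follows is a judgement. In this assay a fall beyond the scatter is expected, estimated at a number 0.45 log units lower from compound 2 to compound 3 (beyond the scatter) in size. For compound 3 the estimated value is 1.85 with an expected range from 1.55 to 2.15 on this scale.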

Compound 3, partition coefficient: 1.75
The estimate for compound 3 lay 0.10 log units above the measured number; low and high end bracket the measured number.
By their numbers in this assay, from the lowest: compounds 1 and 3 (each within the scatter of the next); then compound 2.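

In this assay, isopropyl in place of butyl on a saturated chain carbon bound to a carbon with a double bond to nitrogen gives a number 0.55 log units lower from compound 2 to compound 3 (beyond the scatter), with the rest of the structure unchanged. Unlike the gap between compound 1 and compound 2, this step can be tied to one structural change, and it shows that the reading responds to the group at this place. No measurement here gives a reason for the step.

Butyl, with 4 heavy atoms, and isopropyl, with 3, differ in both size and shape, so the pair cannot show which of the two matters. Going by these compounds, a propyl group at this place would match isopropyl in heavy atoms with an unbranched chain, and both its reading and that of a longer chain such as hexyl remain open.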